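Carbamate in Place of Ester on the Shared Core

The source may hold more compounds than are shown below. What is called first, only, known or untested is meant among the compounds shown, and "the series" means these compounds.

Measured compounds:
compound 1, `CCCCCC(=O)OCC1CN(C(=O)c2cc(OC)c(OC)c(OC)c2)CCN1C(=O)c1cc(OC)c(OC)c(OC)c1`: 290 nM
compound 2, `CCCCCCCCCC(=O)OCC1CN(C(=O)c2cc(OC)c(OC)c(OC)c2)CCN1C(=O)c1cc(OC)c(OC)c(OC)c1`: 2820 nM

In a functional assay (Oryctolagus cuniculus) for inhibition of platelet-activating factor receptor (Cavia porcellus) (a lower number here means a stronger inhibitor, a higher number a weaker inhibitor), compound 1 gives 290 nM, the lowest of the two numbers; compound 2 gives 2820 nM. Among the compounds with values here, the one known step, a 9.7-fold higher number from compound 1 to compound 2 (0.99 log units; beyond the scatter), shows that lengthening the chain weakens inhibition. Compound 3, `CCCCCN(CCCCC)C(=O)OCC1CN(C(=O)c2cc(OC)c(OC)c(OC)c2)CCN1C(=O)c1cc(OC)c(OC)c(OC)c1`, differs from compound 1 by dipentylamino in place of pentyl on a carbonyl carbon. Within the data shown here, no measured step matches this change exactly, but as with compound 2 the change adds chain atoms, so a weaker inhibitor is expected, with the step from compound 1 estimated as a 5.2-fold higher number from compound 1 to compound 3 (0.71 log units; beyond the scatter). Compound 3 is therefore expected to give 1500 nM, within 400 nM to 6000 nM.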

Compound 3, half-maximal inhibitory concentration: 11400 nM
The estimate for compound 3 lay 7.6-fold (0.88 log units) below the measured number; measured number above the stated range.
By their numbers in this assay, from the lowest: compound 1; then compound 2; then compound 3.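

Swapping pentyl for dipentylamino on this carbonyl carbon turns the ester into a carbamate and produces a 39-fold higher number from compound 1 to compound 3 (1.59 log units; beyond the scatter) as a far larger loss of inhibition than the earlier chain lengthening. Compound 3 also falls behind the nonyl ester, with a 4.0-fold higher number from compound 2 to compound 3 (0.61 log units; beyond the scatter) as a further loss. Nothing measured here explains this weakening.

From the compounds shown here alone, whether the loss belongs to the carbamate link itself or to its two long chains stays open. A carbamate carrying dimethylamino would help separate the two.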